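Chalcones on a dihydroxyphenyl ketone: toward a benzyloxy analogue

The compounds below may be only part of what the source reports. "The series", "measured", "known", "first", "only" and "open" are said of these compounds alone.

Compounds measured so far:
Compound 1, `COc1ccc(/C=C/C(=O)c2ccc(O)cc2O)c(OC)c1`: 19500 nM
Compound 2, `O=C(/C=C/c1ccc(Br)cc1)c1ccc(O)cc1O`: "not determined" (no result reported)
Compound 3, `O=C(/C=C/c1ccc(C(F)(F)F)cc1)c1ccc(O)cc1O`: "not determined" (no result reported)

The three compounds share a common core, an enone linking a substituted phenyl ring to the dihydroxyphenyl ketone seen in compound 1. In a functional assay on MCF7 cells (Homo sapiens) for inhibition, read by sulforhodamine B assay, with a stated time of 48 h (a higher number here means a weaker inhibitor of growth, a lower number a stronger inhibitor of growth), compound 1 gives 19500 nM. For compound 2 the outcome in this assay is "not determined" (no result reported), and for compound 3 it is likewise "not determined" (no result reported). For the measured compounds named here, compound 3 therefore stands on no number at all; the only figure in hand belongs to compound 1, and no step between measured compounds can be read from these data.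

The next compound, compound 4 `O=C(/C=C/c1ccc(OCc2ccccc2)cc1)c1ccc(O)cc1O`, differs from compound 3 in one place: benzyloxy in place of trifluoromethyl on an aromatic carbon. Going by the values given here, since compound 3 has no result, the size or direction of this change in this assay cannot be anchored on a measured step, and the expectation for compound 4 rests only on the single value of compound 1, which shares the same core. Compound 4 is expected to give about 12000 nM in this assay, with a plausible range from 3000 nM to 40000 nM.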

Compound 4, concentration for 50% growth inhibition: 8000 nM
The estimate for compound 4 lay 1.5-fold (0.18 log units) above the measured number; the range from low to high includes it.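

For the compounds shown here, no step from compound 3 to compound 4 can be read in this assay, where compound 4 gives 8000 nM. The compounds shown leave open how benzyloxy compares with trifluoromethyl on the shared core in this assay. Nothing in hand offers an explanation for the value of compound 4.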